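Piperidin-1-yl for thiomorpholin-4-yl on the thiocarbonyl carbon

The compounds below may be only part of what the source reports. "The series", "measured", "known", "first", "only" and "open" are said of these compounds alone.

Measured compounds:
compound 1 `Cc1ccnc(/C(N)=N/NC(=S)N2CCSCC2)c1`: 7200 nM in a functional assay on A-431 cells (Homo sapiens) for cytotoxicity, read by MTT assay, with a stated time of 72 h; on this read-out lower numbers stand for stronger inhibition and higher numbers for weaker inhibition
compound 2 `N/C(=N\NC(=S)N1CCSCC1)c1ccccn1`: 6700 nM in this assay

Compound 1 stands at the highest of the two numbers, but its nearest neighbour, compound 2, sits within the scatter of it: the step of a 1.1-fold lower number from compound 1 to compound 2 (0.03 log units; within the scatter) corresponds to hydrogen in place of methyl on an aromatic carbon and shows no difference beyond repeat variation. No order between compound 1 and compound 2 can be read from these two numbers.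

Compound 3 `Cc1ccnc(/C(N)=N/NC(=S)N2CCCCC2)c1` is not yet measured. It differs from compound 1 by piperidin-1-yl in place of thiomorpholin-4-yl on a thiocarbonyl carbon. Going by the values given here, the single measured step concerns the aromatic methyl, not the group on the thiocarbonyl carbon, so it does not bear on this change; there is no measured pair in which thiomorpholin-4-yl is exchanged for piperidin-1-yl. With nothing pointing either way, the expectation for compound 3 is a number close to that of compound 1, that is a step of no change at the digits printed from compound 1 to compound 3 (within the scatter) that is expected to lie within the scatter. Compound 3 is thus estimated at 7200 nM in this assay, with a range from 2800 nM to 18000 nM.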

Compound 3, half-maximal inhibitory concentration: 18900 nM
Beside the measured number, compound 3's estimate is 2.6-fold (0.42 log units) below it, and the stated range ends below it.
By their numbers in this assay, from the lowest: compounds 2 and 1 (each within the scatter of the next); then compound 3.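

In this assay, going by these compounds alone, the group on the thiocarbonyl carbon is the first place where a single exchange gives a step beyond the scatter: piperidin-1-yl in place of thiomorpholin-4-yl gives a 2.6-fold higher number from compound 1 to compound 3 (0.42 log units; beyond the scatter). Within the data shown here, the only earlier step, at the aromatic carbon, was a 1.1-fold lower number from compound 1 to compound 2 (0.03 log units; within the scatter), so that change showed no difference beyond repeat variation. The two rings have the same size and the same count of heavy atoms, and they differ in one ring atom, carbon in piperidin-1-yl and sulfur in thiomorpholin-4-yl, so the number at this position responds to a change of that one ring atom, with weaker inhibition for the piperidin-1-yl compound, though the step is modest and rests on a single pair.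

Still open, on these data alone, is whether morpholin-4-yl, with oxygen as the second ring hetero atom, or an open-chain dimethylamino group on the thiocarbonyl carbon would fall nearer compound 1 or compound 3, and whether the same exchange on compound 2 would give a step of like size. No measurement is available that explains the step from thiomorpholin-4-yl to piperidin-1-yl.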